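This account rests on a few compounds, and the source may have more. Where it says the series, first, only, none or still open, it means among the compounds named here.

Measured so far:
- compound 1 `COc1ccc2c(c1)OC(c1cc(OC)c(OC)c(OC)c1)C(C(N)=O)=C2` — > 50000 nM
- compound 2 `COc1ccc2c(c1)OC(c1cc(OC)c(OC)c(OC)c1)C(C(=O)Nc1ccccc1)=C2` — 17500 nM
- compound 3 `COc1ccc2c(c1)OC(c1cc(OC)c(OC)c(OC)c1)C(C(=O)N(C)OC)=C2` — 11700 nM

In a functional assay for inhibition of nuclear factor NF-kappa-B complex (Homo sapiens) (on this read-out higher numbers stand for weaker inhibition and lower numbers for stronger inhibition), compound 1 gives only a limit, (the limit of > 50000 nM in this assay, at which 1 of the 3 values shown sits). Among the two numbers, compound 3 gives the lowest, and compound 2 sits within the scatter of it, so neither is set apart from the other.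

Compound 4 `CCOCC1=Cc2ccc(OC)cc2OC1c1cc(OC)c(OC)c(OC)c1` differs from compound 3 in one place: ethoxymethyl in place of methoxy(methyl)carbamoyl on a double-bonded ring carbon. The measured steps all change the substituent on the amide nitrogen while keeping the carbonyl: an at least 2.8-fold lower number from compound 1 to compound 2 (0.45 log units; beyond the scatter), an at least 4.2-fold lower number from compound 1 to compound 3 (0.63 log units; beyond the scatter), and a 1.5-fold lower number from compound 2 to compound 3 (0.17 log units; within the scatter). None of them removes the carbonyl, so they bear only indirectly on the step to compound 4. Within the data shown here, the two steps beyond the scatter both go from a bare amino group toward a substituted one; the change to compound 4 removes that whole group and replaces it with ethoxymethyl, which has no measured precedent here.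

For compound 4 in this assay the expected step is a 2.1-fold higher number from compound 3 to compound 4 (0.33 log units; beyond the scatter), with the number estimated at 25000 nM, between 8000 nM and 80000 nM.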

Compound 4, half-maximal inhibitory concentration: 21300 nM
Beside the measured number, compound 4's estimate is 1.2-fold (0.07 log units) above it; low and high end bracket the measured number.
By their numbers in this assay, from the lowest: compounds 3, 2 and 4 (each within the scatter of the next). At a limit, above all of these: compound 1.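

In this assay, ethoxymethyl on this double-bonded ring carbon has neither a carbonyl nor a nitrogen, and the series still holds within the scatter, with a 1.8-fold higher number from compound 3 to compound 4 (0.26 log units; within the scatter) and a 1.2-fold higher number from compound 2 to compound 4 (0.09 log units; within the scatter), so in these compounds the carbonyl is not needed to keep a number of this size. Only carbamoyl stands apart at this carbon, with an at least 2.3-fold lower number from compound 1 to compound 4 (0.37 log units; beyond the scatter). Compound 1 gives a limit and not a number, so that step is a bound only: the limit of > 50000 nM in this assay, at which 1 of the 4 values shown sits.

Open, going by these compounds, is whether a hydroxymethyl, an amine, a carboxylic acid or a longer ether chain on this carbon would give a number beyond the scatter of compound 3. Also open, on these data alone, is whether the picture holds with another group on the ring atom that bears a large group.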